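From Isopropyl to Pentan-3-yl: An Expected Step

A few compounds are considered here, and "the series" means these few. Any claim that something is new, unique, unknown or untested is made for them only; others in the source may bear on it.

Measured in a physicochemical assay for solubility, in phosphate buffer, measured as kinetic solubility, with a stated time of 24 h, at pH 6.5; on this read-out lower numbers stand for lower solubility and higher numbers for higher solubility:
- Compound 1 `CC(C)Oc1cc(Oc2ccc(S(C)(=O)=O)cc2)cc(-c2cccc(=O)[nH]2)c1`: 11000 nM
- Compound 2 `Cc1cc(=O)[nH]c(-c2cc(Oc3ccc(S(C)(=O)=O)cc3)cc(OC(C)C)c2)n1`: 15000 nM
- Compound 3 `CC(C)Oc1cc(Oc2cnc(C(=O)N(C)C)nc2)cc(-c2nccc(=O)[nH]2)c1`: 332000 nM

Of these three, compound 3 stands highest at 332000 nM, beyond the scatter from both of the others. Compound 1 and compound 2 lie within the scatter of each other.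

Compound 4 `CCC(CC)Oc1cc(Oc2cnc(C(=O)N(C)C)nc2)cc(-c2nccc(=O)[nH]2)c1` has not yet been measured. It differs from compound 3 in one place: pentan-3-yl in place of isopropyl on an oxygen on an aromatic ring. Pentan-3-yl thus takes the place of isopropyl on an oxygen on an aromatic ring.

Within the data shown here, only one measured step bears on the comparison, and only weakly: a 1.4-fold higher number from compound 1 to compound 2 (0.13 log units; within the scatter). That step lies within the scatter and concerns a ring group on an aromatic carbon, while the isopropyl group stays unchanged. Among the measured compounds shown here, no measured pair shows a change of the group on the oxygen, so the expectation is a judgement rather than a trend. It starts from compound 3 at 332000 nM and from the added carbons, and it points to a moderately lower number. The expected change is a 2.6-fold lower number from compound 3 to compound 4 (0.41 log units; beyond the scatter). For compound 4, the estimated value in this assay is 130000 nM, with an expected range from 40000 nM to 350000 nM.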

Compound 4, solubility: 469000 nM
Estimate against measurement, compound 4: 3.6-fold (0.56 log units) below, and the stated range ends below it.
By their numbers in this assay, from the lowest: compounds 1 and 2 (each within the scatter of the next); then compounds 3 and 4 (each within the scatter of the next).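

In this assay, among these compounds, the change to pentan-3-yl in place of isopropyl on an oxygen on an aromatic ring gave a 1.4-fold higher number from compound 3 to compound 4 (0.15 log units; within the scatter) as the only measured step at this position. The earlier compounds shown here all carry isopropyl on this oxygen, so they could not show how this read-out responds to a change of that group; this pair shows that, for these two groups on this core, the read-out does not separate them. Nothing at hand explains why the larger group leaves the two compounds within the scatter of each other.

What the compounds shown leave open is how far this one pair can be generalised: a longer, unbranched chain, a cyclopentyl ring, or a chain ending in an amine or a carboxylic acid on the same oxygen could each give a different answer. Going by these compounds, it also remains open whether pentan-3-yl would give a similar step on the cores of compound 1 and compound 2, where the group on the oxygen is still isopropyl.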